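A Single Fluoro Step on Compound 1

The source may report more compounds than this note shows. Statements on the series, on what has been measured and on what is new or still open speak of the compounds shown alone.

For the measured compounds named here, in a functional assay on HL-60 cells (Homo sapiens) for inhibition, read by MTT assay, with a stated time of 72 h (on this read-out higher numbers stand for weaker inhibition and lower numbers for stronger inhibition), compound 1 `COc1cc(OC)cc(N2CCN(C(=O)c3onc(C)c3-c3ccccc3)CC2)c1` gives 152 nM as the only true number among the compounds measured so far. Compound 2 `CC(=O)c1ccc(N2CCN(C(=O)c3oc(C)nc3-c3ccccc3)CC2)cc1` is reported as "not active" (no number reported) with no number attached. Compound 3 `CCc1nc(-c2ccc(OC)cc2)c(C(=O)N2CCN(c3cccc(Cl)c3)CC2)o1` reads > 1000 nM and this value is a limit. Compound 4 `COc1cc(OC)cc(N2CCN(C(=O)c3onc(C)c3-c3ccc(F)cc3)CC2)c1` still awaits measurement. It differs from compound 1 by going from phenyl to 4-fluorophenyl fluoro in place of hydrogen on an aromatic carbon on the shared core, with fluoro in place of hydrogen on an aromatic carbon. Going by the values given here, no measured pair shows this change. The expected outcome in this assay is a 1.0-fold lower number from compound 1 to compound 4 (0.01 log units; within the scatter) in size, which means no step beyond the usual scatter in either direction. Compound 4 is estimated at 150 nM within a range of 50 nM to 450 nM for now.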

Compound 4, half-maximal inhibitory concentration: 475 nM
Compound 4: middle estimate off by 3.2-fold (0.50 log units), on the low side; measured number above the stated range.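

In this assay, this position responds to a single added atom: fluoro in place of hydrogen gives a 3.1-fold higher number from compound 1 to compound 4 (0.49 log units; beyond the scatter). For the compounds shown here, no earlier pair could show this, and it means that even one fluorine, on the aromatic carbon para to a large group, weakens inhibition here. Compound 4 gives a true number, so the step can be read in full, whereas compound 3 sits at a limit: the limit of > 1000 nM in this assay, at which 1 of the 4 values shown sits.

Going by these compounds, whether bromo or an amine at this place would weaken inhibition further remains open.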